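Amide substituent trimming in a thiazole antagonist series

The source may report more compounds than this note shows. Statements on the series, on what has been measured and on what is new or still open speak of the compounds shown alone.

Three amides on the shared core have been measured in a functional assay for antagonist activity at thyroid hormone receptor beta (Homo sapiens), read by fluorescence polarization, with a stated time of 3 h; on this read-out higher numbers stand for weaker inhibition and lower numbers for stronger inhibition. Compound 1 `CC1(C)CC2CC(C)(CN2C(=O)c2sc(-c3ccc(S(C)(=O)=O)c([N+](=O)[O-])c3)nc2C(F)(F)F)C1` gives 2100 nM; compound 2 `CN(Cc1cccc(F)c1)C(=O)c1sc(-c2ccc(S(C)(=O)=O)c([N+](=O)[O-])c2)nc1C(F)(F)F` gives 2800 nM; compound 3 `CC1CCN(C(=O)c2sc(-c3ccc(S(C)(=O)=O)c([N+](=O)[O-])c3)nc2C(F)(F)F)CC1` gives 310 nM, the lowest of the three numbers. Its margins are both beyond the scatter: a 6.8-fold lower number from compound 1 to compound 3 (0.83 log units; beyond the scatter) and a 9.0-fold lower number from compound 2 to compound 3 (0.96 log units; beyond the scatter). Both steps swap a larger amine for 4-methylpiperidin-1-yl, so they say that the smaller saturated amine is tolerated well, but neither of them tests the methyl on that ring by itself.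

Compound 4 `CS(=O)(=O)c1ccc(-c2nc(C(F)(F)F)c(C(=O)N3CCCCC3)s2)cc1[N+](=O)[O-]` carries that test: hydrogen in place of methyl on a saturated ring carbon. Among the compounds with values here, no measured step removes a single carbon from a saturated ring carbon, so the expectation can lean only on the two steps above, which point towards the smaller amines and give no sign that the methyl is needed. The step from compound 3 to compound 4 is therefore expected to be small, a 1.5-fold higher number from compound 3 to compound 4 (0.16 log units; within the scatter), not clearly beyond the scatter in either direction. Compound 4 is estimated at 450 nM, within a range of 200 nM to 1200 nM.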

Compound 4, half-maximal inhibitory concentration: 660 nM
For compound 4 the middle estimate is 1.5-fold (0.17 log units) below the measured one; low and high end bracket the measured number.
By their numbers in this assay, from the lowest: compound 3; then compound 4; then compounds 1 and 2 (each within the scatter of the next).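

In this assay the methyl on this saturated ring carbon, three ring bonds from the ring nitrogen, is not neutral: hydrogen in its place gives a 2.1-fold higher number from compound 3 to compound 4 (0.33 log units; beyond the scatter) and the step, though modest, clears the scatter. The piperidin-1-yl amide still stands apart from the two larger amides, with a 4.2-fold lower number from compound 2 to compound 4 (0.63 log units; beyond the scatter) and with a 3.2-fold lower number from compound 1 to compound 4 (0.50 log units; beyond the scatter) so the advantage of the smaller saturated amine over those two does not rest on the methyl alone. Nothing at hand accounts for the methyl step.

Open, on these data alone, is whether ethyl or hydroxyl on the same ring carbon would go further than methyl or fall back towards hydrogen. Also open, as far as these compounds go, is whether a methyl would give a similar step on a smaller amine such as pyrrolidin-1-yl.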